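Swapping Fluoro for Sulfamoyl on the Lowest-Number Compound

The source may hold more compounds than are shown below. What is called first, only, known or untested is meant among the compounds shown, and "the series" means these compounds.

In a functional assay on K562 cells (Homo sapiens) for antiproliferative activity, read by sulforhodamine B assay, with a stated time of 72 h (a lower number here means a stronger inhibitor, a higher number a weaker inhibitor), compound 1 `S=C(NNc1nncc2ccccc12)Nc1ccccc1` gives 76 nM and compound 2 `O=C1CS/C(=N/Nc2nncc3ccccc23)N1` gives 85 nM as its reading. Compound 3 `Fc1ccc(Nc2nncc3ccccc23)cc1` gives 6.7 nM and so has the lowest number of the three, with its gaps to both others beyond the usual scatter.

Compound 4 `NS(=O)(=O)c1ccc(Nc2nncc3ccccc23)cc1` differs from compound 3 by a single change sulfamoyl in place of fluoro on an aromatic carbon with sulfamoyl in place of fluoro on an aromatic carbon, para to a large group. Going by the values given here, no two measured compounds differ in just one place, so nothing here shows directly what this swap does, and any forecast must stay loose.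

Among the compounds with values here, compound 3 already stands at 6.7 nM with the lowest number so far, which makes a rise the likelier direction for a new group. In this assay the expected step is a moderate rise beyond the scatter (a 3.7-fold higher number from compound 3 to compound 4 (0.57 log units; beyond the scatter)) rather than a fall. For compound 4 the estimated value is 25 nM with an expected range from 5 nM to 120 nM as the likely span.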

Compound 4, half-maximal inhibitory concentration: 14 nM
Compound 4: the middle estimate sits 1.8-fold (0.25 log units) above what was measured; the measured number falls inside the stated range.
By their numbers in this assay, from the lowest: compound 3; then compound 4; then compounds 1 and 2 (each within the scatter of the next).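

In this assay, going by these compounds alone, putting sulfamoyl in place of fluoro gives a 2.1-fold higher number from compound 3 to compound 4 (0.32 log units; beyond the scatter) and is the first step here that isolates a single place on the molecule. It shows that this aromatic carbon, para to a large group, can take a group of 4 heavy atoms with 1 hydrogen-bond donor and 2 hydrogen-bond acceptors instead of a lone fluorine, at the price of only a modest rise in the number. No measurement shown here bears on what lies behind this step.

With a single swap at this place, the result does not show how other groups, such as an amine, a carboxylic acid or a longer chain, would behave there. It also leaves open whether sulfamoyl would produce a step of similar size on the core of compound 1 or compound 2.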